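Changing the group on the carbonyl carbon

This account rests on a few compounds, and the source may have more. Where it says the series, first, only, none or still open, it means among the compounds named here.

In a functional assay on HepG2 cells (Homo sapiens) for inhibition, read by MTT assay, with a stated time of 24 h (a higher number here means a weaker inhibitor of growth, a lower number a stronger inhibitor of growth), compound 1 (`COc1ccccc1C(=O)n1c(-c2cn(C)c3ccccc23)nc2ccccc21`) gives 31800 nM and compound 2 (`COc1ccc2c(c1)c(-c1nc3ccccc3n1C(=O)c1ccccc1OC)cn2C`) gives 23600 nM with the two numbers inside the scatter of each other. Compound 2 therefore holds no separate place in this pair. For the measured compounds named here, the only measured step (a 1.3-fold lower number from compound 1 to compound 2 (0.13 log units; within the scatter)) comes with methoxy in place of hydrogen on an aromatic carbon and lies within the scatter.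

Compound 3 (`COc1ccc2c(c1)c(-c1nc3ccccc3n1C(=O)c1cccc(Br)c1)cn2C`) carries 3-bromophenyl in place of 2-methoxyphenyl on a carbonyl carbon. Going by the values given here, no measured step involves the group on that carbonyl carbon, so the data give no direct size for this change. Among the compounds with values here, the one step available is a different change in a different place and serves only as a weak guide.

With compound 2 at 23600 nM as the starting point, no shift beyond the scatter is expected in this assay (a 1.2-fold lower number from compound 2 to compound 3 (0.07 log units; within the scatter)) and the range is kept wide. For compound 3 the estimated value is 20000 nM (expected range 8000 nM to 50000 nM).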

Compound 3, concentration for 50% growth inhibition: 51300 nM
For compound 3 the middle estimate is 2.6-fold (0.41 log units) below the measured one, outside the stated range (above it).
By their numbers in this assay, from the lowest: compounds 2, 1 and 3 (each within the scatter of the next, the first and the last beyond it).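

In this assay, for the compounds shown here, the group on the carbonyl carbon is the first place to give a step beyond the scatter: 3-bromophenyl in place of 2-methoxyphenyl gives a 2.2-fold higher number from compound 2 to compound 3 (0.34 log units; beyond the scatter), a modest move towards weaker growth inhibition, whereas methoxy in place of hydrogen on an aromatic carbon, a 1.3-fold lower number from compound 1 to compound 2 (0.13 log units; within the scatter), did not separate its pair. The exchange alters both the substituent and its numbered place on the phenyl, as the names 2-methoxyphenyl and 3-bromophenyl show, so this single step cannot be divided between the two. No measurement available here accounts for the step.

Open, on these data alone, is whether plain phenyl, 2-bromophenyl or 3-methoxyphenyl on the carbonyl carbon would separate the identity of the substituent from its place on the ring. Also open, as far as these compounds go, is how growth inhibition responds when the aromatic ring on the carbonyl carbon gives way to a non-aromatic group such as a morpholine or a longer alkyl chain, or when the phenyl carries a carboxylic acid.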